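Swapping nitro for methoxy in two weak urea series

This account rests on a few compounds, and the source may have more. Where it says the series, first, only, none or still open, it means among the compounds named here.

The four compounds here are ureas carrying a trimethoxyphenyl group on one side and a second aromatic ring on the other. Compound 1, `COc1ccc(N(C)C(=O)N(C)c2cc(OC)c(OC)c(OC)c2)cc1`, and compound 2, `COc1cc(N(C)C(=O)N(C)c2ccc([N+](=O)[O-])cc2)cc(OC)c1OC`, share one core; compound 3, `COc1cc(NC(=O)Nc2ccc([N+](=O)[O-])cc2)cc(OC)c1OC`, and the not yet measured compound 4, `COc1ccc(NC(=O)Nc2cc(OC)c(OC)c(OC)c2)cc1`, share another. The difference between the two cores is not broken down here.

All were tested, or are to be tested, in a functional assay on Daoy cells (Homo sapiens) for cytotoxicity, read by MTT assay, with a stated time of 72 h; on this read-out higher numbers stand for weaker inhibition and lower numbers for stronger inhibition. In this assay compound 1 reaches only the limit of the assay, >= 125000 nM. Compound 2 likewise reaches only the limit, >= 125000 nM. Among the measured compounds shown here, compound 3 is the single compound with a true number, giving 70800 nM in this assay, so it stands alone against (the limit of >= 125000 nM in this assay, at which 2 of the 3 values shown sit).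

From compound 2 to compound 1 the change is methoxy in place of nitro on an aromatic carbon, and its effect is a step that the two limits leave unreadable from compound 2 to compound 1. The change from compound 3 to compound 4 is methoxy in place of nitro on an aromatic carbon, the same change as before, now on the second core.

Because compound 3 already sits at 70800 nM, a weak value, compound 4 is expected to stay in the same weak region. The step expected here, a 1.4-fold higher number from compound 3 to compound 4 (0.15 log units; within the scatter), is estimated to be small. Compound 4 is therefore estimated at 100000 nM in this assay, within 35000 nM to 250000 nM, with a real chance that only a limit is reported.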

Compound 4, half-maximal inhibitory concentration: 14900 nM
Estimate against measurement, compound 4: 6.7-fold (0.83 log units) above, and the stated range ends above it.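

In this assay, replacing nitro with methoxy on the core shared by compound 3 and compound 4 gives a 4.8-fold lower number from compound 3 to compound 4 (0.68 log units; beyond the scatter), a real if modest gain, though compound 4 still needs a high concentration to act on these cells. Among the compounds shown here, the same replacement from compound 2 to compound 1 cannot be read, because neither compound gives a true number and no step can be sized between two limits: the limit of >= 125000 nM in this assay, at which 2 of the 4 values shown sit. The gain on the one core therefore does not show that the change carries over to the other: the data neither confirm nor rule out a similar step there, and a single readable step cannot establish a trend or explain why the number falls.

On these data alone, only nitro and methoxy appear at this place, on an aromatic carbon para to a large group, so it remains open whether the gain reflects the loss of nitro, the arrival of methoxy, or both. An amine or a longer chain such as ethoxy at the same place on the core of compound 3 could help separate these possibilities, and would show whether the number can fall further.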